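From dimethylamino to pyrrolidin-1-yl on a carbonyl carbon

The compounds below may be only part of what the source reports. "The series", "measured", "known", "first", "only" and "open" are said of these compounds alone.

Measured in a functional assay on HL-60 cells (Homo sapiens) for antiproliferative activity, read by MTT assay, with a stated time of 48 h; a higher number here means a weaker inhibitor, a lower number a stronger inhibitor:
- compound 1 `CC(C)=CCC[C@]1(C)/C=C/[C@@H](OC(=O)C=C(C)C)[C@](C)(O)/C=C/C(=O)/C(CCl)=C\C1`: 160 nM
- compound 2 `CC(C)=CCC[C@]1(C)/C=C/[C@@H](OC(=O)C=C(C)C)[C@](C)(O)/C=C/C(=O)/C(C(=O)N(C)C)=C\C1`: 3340 nM

Of these two numbers, compound 2 holds the higher at 3340 nM. Compound 3 `CC(C)=CCC[C@]1(C)/C=C/[C@@H](OC(=O)C=C(C)C)[C@](C)(O)/C=C/C(=O)/C(C(=O)N2CCCC2)=C\C1` follows from compound 2 through one change: pyrrolidin-1-yl in place of dimethylamino on a carbonyl carbon. In words, pyrrolidin-1-yl stands in place of dimethylamino on a carbonyl carbon. Within the data shown here, the only measured step is a 21-fold higher number from compound 1 to compound 2 (1.32 log units; beyond the scatter). That large step replaced chloromethyl with dimethylcarbamoyl on a double-bonded ring carbon, whereas the carbonyl remains in the new change, so it sets no size for this one. Among the measured compounds shown here, no measured step replaces dimethylamino. In this assay, the expected 1.1-fold lower number from compound 2 to compound 3 (0.05 log units; within the scatter) therefore lies within the scatter, with no firm direction. Compound 3 is estimated at 3000 nM, with an expected range of 1300 nM to 7000 nM.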

Compound 3, half-maximal inhibitory concentration: 12300 nM
Estimate against measurement, compound 3: 4.1-fold (0.61 log units) below; measured number outside the range, above it.
By their numbers in this assay, from the lowest: compound 1; then compound 2; then compound 3.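

In this assay, the carbonyl position proves sensitive to the group on its nitrogen and not only to the swap from chloromethyl: pyrrolidin-1-yl in place of dimethylamino gives a 3.7-fold higher number from compound 2 to compound 3 (0.57 log units; beyond the scatter), a step beyond the scatter even though both groups keep the carbonyl on the double-bonded ring carbon. Measured from the chloromethyl of compound 1, (pyrrolidin-1-yl)carbonyl gives a 77-fold higher number from compound 1 to compound 3 (1.89 log units; beyond the scatter), which goes further than the dimethylcarbamoyl step of a 21-fold higher number from compound 1 to compound 2 (1.32 log units; beyond the scatter). No measurement given here accounts for the difference between these two groups.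

Among these compounds, with only two groups on this carbonyl, no trend can be claimed for the group on its nitrogen. As far as these compounds go, it remains open whether a morpholin-4-yl or a plain amino group there, or a hydroxymethyl or a carboxylic acid in place of chloromethyl, would come closer to compound 1.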